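This account rests on a few compounds, and the source may have more. Where it says the series, first, only, none or still open, it means among the compounds named here.

Compound 1 `Cn1c(=O)c(S(=O)(=O)c2ccc(F)cc2F)cc2cnc(Nc3cccc4[nH]ccc34)nc21`: 750 nM
Compound 2 `Cn1c(=O)c(S(=O)(=O)c2ccc([N+](=O)[O-])cc2F)cc2cnc(Nc3ccc4[nH]ccc4c3)nc21`: 400 nM

In a functional assay on DU-145 cells (Homo sapiens) for inhibition, read by trypan blue exclusion, with a stated time of 72 h (a higher number here means a weaker inhibitor, a lower number a stronger inhibitor), compound 1 gives 750 nM, while compound 2 gives 400 nM. Compound 2 has the lower of the two numbers, but its gap to compound 1 lies within the usual scatter, so the two cannot be told apart. Compound 3 `Cn1c(=O)c(S(=O)(=O)c2ccc(O)cc2)cc2cnc(Nc3ccc4[nH]ccc4c3)nc21` has not been measured. It differs from compound 2 in one place: 4-hydroxyphenyl in place of 2-fluoro-4-nitrophenyl on a sulfonyl sulfur. Among the compounds with values here, no measured pair shows a change of this kind, so nothing can be drawn on directly. Compound 3 is expected to show a step of a 1.6-fold higher number from compound 2 to compound 3 (0.21 log units; within the scatter), small and toward a weaker inhibitor, if beyond the scatter at all. Compound 3 is therefore estimated at 650 nM in this assay, with a range from 250 nM to 1700 nM.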

Compound 3, half-maximal inhibitory concentration: 250 nM
Compound 3: middle estimate off by 2.6-fold (0.41 log units), on the high side; the measured number falls inside the stated range.
By their numbers in this assay, from the lowest: compounds 3, 2 and 1 (each within the scatter of the next, the first and the last beyond it).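

In this assay, within the data shown here, 4-hydroxyphenyl in place of 2-fluoro-4-nitrophenyl on a sulfonyl sulfur gives a 1.6-fold lower number from compound 2 to compound 3 (0.20 log units; within the scatter) and is the first one-place comparison at this position. This substituent can therefore be exchanged for a smaller one carrying a hydroxyl, with no fluorine or nitro group, without a difference that stands clear of the scatter. No measurement on hand offers an explanation for this result. The compounds shown leave open whether the hydroxyl, the fluorine or the nitro group matters on its own. They also leave open how an amine or a carboxylic acid in place of the hydroxyl would read.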